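From Methylamino to Imidazolyl on the Shared Core

The source may report more compounds than this note shows. Statements on the series, on what has been measured and on what is new or still open speak of the compounds shown alone.

Among the measured compounds shown here, compound 2, `CCC[C@@H](CCO)Nc1nc(N)nc(C)c1Cc1ccc(CNC)cc1OC`, is the only member of this small set with a numerical result in an assay on HEK293 cells for agonist activity at Toll-like receptor 8 (Homo sapiens); a lower number here means that less compound is needed, a higher number that more compound is needed for the effect: compound 2 gives 6460 nM. Compound 1, `CCC[C@@H](CCO)Nc1nc(N)nc(C)c1Cc1ccc(CNCCC(N)=O)cc1OC`, reaches only a limit of the assay in this assay, at > 10000 nM (the limit of > 10000 nM in this assay, at which 1 of the 2 values shown sits). The step of an at least 1.5-fold lower number from compound 1 to compound 2 (0.18 log units; that floor lies within the scatter) therefore marks a change that lies within the scatter, so these two values set no firm direction.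

Compound 3, `CCC[C@@H](CCO)Nc1nc(N)nc(C)c1Cc1ccc(Cn2ccnc2)cc1OC`, has not yet been measured. It differs from compound 2 by 1H-imidazol-1-yl in place of methylamino on a saturated chain carbon bound to an aromatic carbon. For the measured compounds named here, no measured step bears on this kind of exchange; the single measured step, from compound 1 to compound 2, concerns a group on a saturated chain carbon bound to an amine nitrogen and is small. With no directional evidence at hand, compound 3 is expected to land near compound 2, estimated at 6000 nM with a range from 1500 nM to 20000 nM. The expected step of a 1.1-fold lower number from compound 2 to compound 3 (0.03 log units; within the scatter) is thus modest in either direction, and a further limit result cannot be excluded.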

Compound 3, half-maximal effective concentration: 4900 nM
Estimate against measurement, compound 3: 1.2-fold (0.09 log units) above; the range from low to high includes it.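

In this assay, putting 1H-imidazol-1-yl in place of methylamino on a saturated chain carbon bound to an aromatic carbon gives a 1.3-fold lower number from compound 2 to compound 3 (0.12 log units; within the scatter), so the entering group, with one five-membered aromatic ring and 0 hydrogen-bond donors, leaves the number indistinguishable from that of the methylamino compound, whose group has no ring and 1 hydrogen-bond donor. The exchange of (2-carbamoylethyl)amino for 1H-imidazol-1-yl at the same place gives an at least 2.0-fold lower number from compound 1 to compound 3 (0.30 log units; that floor lies within the scatter), which again sets no firm direction. Compound 1 remains a limit of the assay and not a number: the limit of > 10000 nM in this assay, at which 1 of the 3 values shown sits.

The compounds shown leave open whether any group at this place can move the number beyond the scatter, as a carboxylic acid, a dimethylamino group or a longer chain carrying an amine might or might not. They also leave open whether the ring nitrogens of the 1H-imidazol-1-yl group matter at all, a question that a phenyl or a pyrazol-1-yl ring at the same place would address.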